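The source may report more compounds than this note shows. Statements on the series, on what has been measured and on what is new or still open speak of the compounds shown alone.

Measured so far:
compound 1, `CC(=O)c1ccc(Nc2ccnc(SCC(=O)c3ccc(Br)cc3)n2)cc1`, gives 12% in a functional assay on MDA-MB-231 cells (Homo sapiens) for inhibition, read by sulforhodamine B assay, with a stated time of 48 h, tested at 10 uM; a higher number here means more inhibition of growth at the concentration tested, a lower number less inhibition of growth
compound 2, `CC(=O)c1cccc(Nc2ccnc(SCC(=O)c3ccc(-c4ccccc4)cc3)n2)c1`, gives 41% in this assay
compound 3, `COc1ccc(C(=O)CSc2nccc(Nc3cccc(C(C)=O)c3)n2)cc1`, gives 27% in this assay

Compound 2 stands highest of the three, compound 3 being the nearest with a number 14 percentage points lower from compound 2 to compound 3 (beyond the scatter) and compound 1 the furthest below. Compound 4, `CC(=O)c1ccc(Nc2ccnc(SCC(=O)c3ccc(-c4ccccc4)cc3)n2)cc1`, differs from compound 2 by 4-acetylphenyl in place of 3-acetylphenyl on a nitrogen on an aromatic ring. Among the compounds with values here, no measured step covers this change; the only measured step, from compound 2 to compound 3, alters the other aromatic ring. Compound 4 shares its 4-acetylphenyl group with compound 1, whose other ring differs, and there compound 1 gives 12%. The change is therefore expected to cost some inhibition, a number 16 percentage points lower from compound 2 to compound 4 (beyond the scatter). Compound 4 is estimated at 25% in this assay, within 8% to 45%.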

Compound 4, percent growth inhibition at one concentration: 22%
Compound 4: the middle estimate sits 3 percentage points above what was measured; low and high end bracket the measured number.
By their numbers in this assay, from the lowest: compounds 1, 4 and 3 (each within the scatter of the next, the first and the last beyond it); then compound 2.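

With the rest of the molecule unchanged, 4-acetylphenyl in place of 3-acetylphenyl on the nitrogen gives a number 19 percentage points lower from compound 2 to compound 4 (beyond the scatter) in this assay. This shows that where the acetyl group sits matters, at least in this pair. With 4-acetylphenyl held fixed, phenyl in place of bromo on the other ring gives a number 10 percentage points higher from compound 1 to compound 4 (within the scatter), so that swap shows no clear gain here. No available evidence accounts for either result. From the compounds shown here alone, whether 3-acetylphenyl also beats 4-acetylphenyl with bromo or methoxy on the other ring remains open, as does the effect of an amine or a carboxylic acid in place of the acetyl group.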